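This account rests on a few compounds, and the source may have more. Where it says the series, first, only, none or still open, it means among the compounds named here.

Compounds measured so far:
compound 1 `COc1ccc(C(=O)O)cc1OCCCCOc1ccc(C(=O)CC2CCCC2)c(O)c1C`, 1020 nM
compound 2 `Cc1ccc(C(=O)O)cc1OCCCCOc1ccc(C(=O)CC(C)C)c(O)c1C`, only a limit, > 10000 nM

In an assay on HEK293 cells for positive allosteric modulation of metabotropic glutamate receptor 3 (Rattus norvegicus), read by thallium flux, with a stated time of 2.5 min (a lower number here means that less compound is needed, a higher number that more compound is needed for the effect), compound 1 gives 1020 nM. Compound 2 reaches only the limit of this assay, > 10000 nM, so its true value is not known; it sits at the limit of > 10000 nM in this assay, at which 1 of the 2 values shown sits. Compound 3 `COc1ccc(C(=O)O)cc1OCCCCOc1ccc(C(=O)CC(C)C)c(O)c1C` has not been measured. It differs from compound 2 by methoxy in place of methyl on an aromatic carbon, a methoxy in place of methyl on an aromatic carbon. With compound 2 known only as a limit, no step size can be taken from the data; compound 3 is expected to sit near or somewhat under that limit, an estimated step of an at least 1.6-fold lower number from compound 2 to compound 3 (0.22 log units; that floor lies within the scatter). For compound 3 the estimate is 6000 nM, between 1500 nM and 20000 nM.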

Compound 3, half-maximal effective concentration: 737 nM
For compound 3 the middle estimate is 8.1-fold (0.91 log units) above the measured one; the measured number lies below the stated range.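

On an aromatic carbon para to a carboxy group, methoxy in place of methyl gives an at least 13-fold lower number from compound 2 to compound 3 (1.13 log units; beyond the scatter), so a change of this one group can decide whether the effect appears at all. Compound 2 stands only at a limit, so that step is a floor: the limit of > 10000 nM in this assay, at which 1 of the 3 values shown sits. With methoxy present, isopropyl in place of cyclopentyl gives a 1.4-fold lower number from compound 1 to compound 3 (0.14 log units; within the scatter), so these two chain ends cannot be told apart here. Going by these compounds, whether an ethoxy group or a chlorine atom would serve as well as methoxy remains open.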